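Methyl added to the phenylsulfonyl group of compound 1

A few compounds are considered here, and "the series" means these few. Any claim that something is new, unique, unknown or untested is made for them only; others in the source may bear on it.

Measured so far:
compound 1 `COc1cc(Nc2nc3ccccc3nc2S(=O)(=O)c2ccccc2)cc(OC)c1` — 950 nM
compound 2 `Nc1cccc(Nc2nc3ccccc3nc2S(=O)(=O)c2ccccc2)c1` — 1540 nM

In a functional assay on HCT-116 cells (Homo sapiens) for cytotoxicity, read by MTT assay, with a stated time of 72 h (a higher number here means a weaker inhibitor, a lower number a stronger inhibitor), compound 1 gives 950 nM, the lowest of the two numbers; compound 2 gives 1540 nM, a step of a 1.6-fold higher number from compound 1 to compound 2 (0.21 log units; within the scatter) that lies within the scatter. Compound 3 `COc1cc(Nc2nc3ccccc3nc2S(=O)(=O)c2ccc(C)cc2)cc(OC)c1` differs from compound 1 by methyl in place of hydrogen on an aromatic carbon. Going by the values given here, no measured step touches the phenylsulfonyl group, so the one known step gives no direct guide. Compound 3 is therefore expected to show no change beyond the scatter, a step of no change at the digits printed from compound 1 to compound 3 (within the scatter). The estimate for compound 3 is 950 nM, with a range from 450 nM to 2000 nM.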

Compound 3, half-maximal inhibitory concentration: > 50000 nM
Compound 3 was reported as a limit; the forecaster's own chance of this, stated with the estimate: 3%; middle value at least 52-fold (1.72 log units) from the limit.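

In this assay, the phenylsulfonyl group proves sensitive to a small change: methyl in place of hydrogen, on an aromatic carbon para to a large group, gives an at least 52-fold higher number from compound 1 to compound 3 (1.72 log units; beyond the scatter). The value of compound 3 is a limit of the assay, not a number: the limit of > 50000 nM in this assay, at which 1 of the 3 values shown sits. Going by these compounds alone, the only earlier step, on the group carried by the nitrogen, lay within the scatter, so this is the first change to go beyond it.

The compounds shown leave open whether any group at this place has the same result or only methyl does, as a fluorine, a methoxy or an amine there could show. As far as these compounds go, it also remains open whether methyl on another carbon of this ring would act alike.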